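This account rests on a few compounds, and the source may have more. Where it says the series, first, only, none or still open, it means among the compounds named here.

Measured so far:
Compound 1 `CCOc1ccc(NC(=O)c2cn(-c3ccccc3)nc2-c2ccccc2)cc1` — in a functional assay on HCT-116 cells (Homo sapiens) for cytotoxicity, read by MTT assay, with a stated time of 48 h (on this read-out lower numbers stand for stronger inhibition and higher numbers for weaker inhibition), compound 1 gives 620 nM.
Compound 2 `COc1ccc(NC(=O)c2cn(-c3ccccc3)nc2-c2ccc(OC)cc2)cc1` — in this assay compound 2 gives 1520 nM.

Compound 2 holds the higher of these two numbers, and the gap to compound 1 lies beyond the usual scatter. Compound 3 `CCOc1ccc(NC(=O)c2cn(-c3ccccc3)nc2-c2ccc(OC)cc2)cc1` differs from compound 2 by one change: methyl in place of hydrogen on a saturated chain carbon bound to an oxygen on an aromatic ring, that is, methoxy becomes ethoxy on the amide-bearing ring. Among the measured compounds shown here, no measured pair isolates this change, so the expectation rests on little. A small shift toward a lower number is expected, a 1.4-fold lower number from compound 2 to compound 3 (0.14 log units; within the scatter), roughly within the scatter. Compound 3 is estimated at 1100 nM, within a range from 500 nM to 2500 nM.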

Compound 3, half-maximal inhibitory concentration: 970 nM
The estimate for compound 3 lay 1.1-fold (0.05 log units) above the measured number, within the range that was stated.
By their numbers in this assay, from the lowest: compounds 1, 3 and 2 (each within the scatter of the next, the first and the last beyond it).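

In this assay, going from methoxy to ethoxy gives a 1.6-fold lower number from compound 2 to compound 3 (0.20 log units; within the scatter), so this single change, now seen in isolation, produces no shift that can be told from the scatter. Methoxy in place of hydrogen on an aromatic carbon gives a 1.6-fold higher number from compound 1 to compound 3 (0.19 log units; within the scatter), which is also within the scatter. Neither change, taken alone, moves the number clearly at these positions.

On these data alone, whether a longer chain such as propoxy, or an amine in place of the ethoxy, would move the number remains open. Nothing shown here gives a reason for either step.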